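The compounds below may be only part of what the source reports. "The series", "measured", "known", "first", "only" and "open" are said of these compounds alone.

Measured compounds: compound 1 `C/C(=N\NC(=O)c1cnccn1)c1ccccc1O`, compound 2 `CC/C(=N\NC(=O)c1cccc2ccccc12)c1ccccc1O`, compound 3 `CC/C(=N\NC(=O)c1cnccn1)c1ccccc1O`. In a functional assay on HL-60 cells (Homo sapiens) for cytotoxicity, read by MTT assay, with a stated time of 72 h (on this read-out lower numbers stand for stronger inhibition and higher numbers for weaker inhibition), compound 1 gives 22300 nM, compound 2 gives 3500 nM, and compound 3 gives 27000 nM, the highest of the three numbers; compound 1 sits within the scatter of it, compound 2 well below it.

The step to compound 4 `CC/C(=N\NC(=O)c1cccnc1)c1ccccc1O` is pyridin-3-yl in place of pyrazin-2-yl on a carbonyl carbon. Going by the values given here, no measured step touches this position: the only measured step, a 1.2-fold higher number from compound 1 to compound 3 (0.08 log units; within the scatter), concerns the chain and is within the scatter. The values of compound 2 and compound 3 show that a different group on the carbonyl carbon can move the number markedly, but the change here is smaller. Compound 4 is therefore expected at 18000 nM (range 7000 nM to 45000 nM), a step of a 1.5-fold lower number from compound 3 to compound 4 (0.18 log units; within the scatter) that is expected to stay within the scatter.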

Compound 4, half-maximal inhibitory concentration: 4900 nM
Estimate against measurement, compound 4: 3.7-fold (0.57 log units) above; the measured number lies below the stated range.
By their numbers in this assay, from the lowest: compounds 2 and 4 (each within the scatter of the next); then compounds 1 and 3 (each within the scatter of the next).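

On the carbonyl carbon, pyridin-3-yl in place of pyrazin-2-yl keeps the six-membered aromatic ring and the heavy-atom count, yet in this assay it gives a 5.5-fold lower number from compound 3 to compound 4 (0.74 log units; beyond the scatter). This position therefore responds to the exchange of one ring nitrogen for carbon, and the number of compound 4 lies within the scatter of that of compound 2. Nothing at hand explains this step.

Still open, as far as these compounds go, is whether the count of ring nitrogens or their place carries the step. Phenyl or pyridin-4-yl on the carbonyl carbon would separate the two.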